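The source may hold more compounds than are shown below. What is called first, only, known or untested is meant among the compounds shown, and "the series" means these compounds.

Of the compounds shown here, three built on one shared core have been measured in a functional assay on A549 cells (Homo sapiens) for antiproliferative activity, read by MTT assay, with a stated time of 48 h; on this read-out lower numbers stand for stronger inhibition of growth and higher numbers for weaker inhibition of growth. Compound 1 `COC(=O)N1N=C(c2ccc(OC)cc2)CC1c1cc(OC)c(OC)c(OC)c1` gives 3400 nM, and compound 2 `CCOC(=O)N1N=C(c2ccc(OC)cc2)CC1c1cc(OC)c(OC)c(OC)c1` gives 4690 nM. The move between them is a 1.4-fold higher number from compound 1 to compound 2 (0.14 log units; within the scatter), so the two sit level. Compound 3 `CCCOC(=O)N1N=C(c2ccc(OC)cc2)CC1c1cc(OC)c(OC)c(OC)c1` gives only a limit of the assay, > 10000 nM. Within the data shown here, compound 1 therefore stands among the only two compounds with true numbers, with no measured compound clearly better.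

Compound 4 `COC(=O)N1N=C(c2cccc(C)c2)CC1c1cc(OC)c(OC)c(OC)c1` keeps the rest of compound 1 but carries 3-methylphenyl in place of 4-methoxyphenyl on a carbon with a double bond to nitrogen. Among the measured compounds shown here, no measured step touches this place. All of them alter the saturated chain on the oxygen next to the carbonyl group, so they offer only a rough sense of scale. Lengthening that chain gave a 1.4-fold higher number from compound 1 to compound 2 (0.14 log units; within the scatter), then an at least 2.1-fold higher number from compound 2 to compound 3 (0.32 log units; beyond the scatter), and overall an at least 2.9-fold higher number from compound 1 to compound 3 (0.46 log units; beyond the scatter). These show that a small edit in this series can leave the number unchanged or push it up to the limit.

With no direct guide, a modest rise is the cautious expectation, and a wide range is needed. The expected move is a 1.5-fold higher number from compound 1 to compound 4 (0.17 log units; within the scatter). For compound 4 the estimated value in this assay is 5000 nM, within an expected range of 1500 nM to 16000 nM.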

Compound 4, concentration for 50% growth inhibition: 300 nM
The estimate for compound 4 lay 17-fold (1.22 log units) above the measured number, and the stated range ends above it.
By their numbers in this assay, from the lowest: compound 4; then compounds 1 and 2 (each within the scatter of the next). At a limit, above all of these: compound 3.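

In this assay, the group on the carbon with a double bond to nitrogen proves far more influential than the small chain edits had suggested: 3-methylphenyl in place of 4-methoxyphenyl gives an 11-fold lower number from compound 1 to compound 4 (1.05 log units; beyond the scatter). This is the first single change shown that lowers the number beyond the scatter, whereas the edits to the chain on the oxygen either left it level or raised it, so this position is where the core of compound 1 has shown room for a clear gain. The swap alters both the group on the phenyl ring and where that group sits, and nothing shown here tells which of the two matters or why the number falls.

From the compounds shown here alone, whether 3-methoxyphenyl or 4-methylphenyl would also give a low number stays open, and that pair would separate the effect of the group from the effect of its location. Going by these compounds, it is equally open whether 3-methylphenyl would bring a similar drop with the ethyl or propyl chain of compounds 2 and 3, and how a larger group such as 3-ethylphenyl or a polar one such as 3-aminophenyl would fare at this position.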